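Methyl to hydrogen on the ring nitrogen: tolerance notes

This account rests on a few compounds, and the source may have more. Where it says the series, first, only, none or still open, it means among the compounds named here.

Four compounds are in view. Compound 1 `Cn1c([N+](=O)[O-])cnc1C(=O)NCc1ccc(F)cc1` and compound 3 `O=C(NCc1ccc(F)cc1)c1ncc([N+](=O)[O-])[nH]1` are measured and differ in one place: hydrogen in place of methyl on an aromatic nitrogen. Compound 2 `CN(C)C(=O)c1ncc([N+](=O)[O-])n1C` and the still unmeasured compound 4 `CN(C)C(=O)c1ncc([N+](=O)[O-])[nH]1` differ by the same kind of change: hydrogen in place of methyl on an aromatic nitrogen. The two places are not worded identically; around compound 1 the ring atom next to the exchanged nitrogen bears a large group, whereas around compound 2 it bears a group of 5 heavy atoms, so the change is of the same kind rather than the same. How the core of compound 2 differs from the core of compound 1 is not broken down here.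

In a toxicity assay on HepG2 cells (Homo sapiens) for inhibition, read by resazurin assay, with a stated time of 24 h (a higher number here means that more compound is tolerated, a lower number that less compound is tolerated), compound 1 reaches only a limit of the assay, > 100000 nM. Compound 3 likewise gives only a limit in this assay, > 100000 nM. For compound 2 this assay also reports only a limit, > 100000 nM. The measured step is therefore a step that the two limits leave unreadable from compound 1 to compound 3. All three values sit at the limit of > 100000 nM in this assay, at which 3 of the 3 values shown sit.

For compound 4 the step expected in this assay is a step that the limit leaves unreadable from compound 2 to compound 4, which rests on compound 3 sitting at the limit of > 100000 nM in this assay, at which 3 of the 3 values shown sit, after the same kind of change, and on compound 2 being read as a limit at > 100000 nM. Compound 4 is expected at 150000 nM, with a range from 70000 nM to 400000 nM, most likely reported again only as a limit.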

Compound 4, half-maximal cytotoxic concentration: > 100000 nM
Compound 4: a limit, no number; the forecaster's own chance of this, stated with the estimate: 85%; the middle value lies beyond the limit too.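

Compound 2 and compound 4 both give only a limit, so no step can be read between them, and the pair adds no size for hydrogen in place of methyl on an aromatic nitrogen. The compounds shown leave open whether that change alters tolerance at all in this assay, as every value stands at the same limit: the limit of > 100000 nM in this assay, at which 4 of the 4 values shown sit.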